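The compounds below may be only part of what the source reports. "The series", "measured", "known", "first", "only" and "open" are said of these compounds alone.

Three compounds in the series have numbers in a physicochemical assay for lipophilicity, measured as octanol-water partition; a higher number here means a more lipophilic compound, a lower number a more polar compound. Compound 3 `CCCCCCCCc1cn(C/C=C(/C)CCC=C(C)C)nn1` gives 6.92, the highest of the three. Compound 1 `CC(C)=CCC/C(C)=C/Cn1cc(-c2ccccc2)nn1` gives 4.91, the nearest number, lower by a step beyond the scatter. Compound 2 `CCCc1cn(CC=C(C)C)nn1` gives 2.47, the furthest, lower again by a step beyond the scatter. Within the data shown here, no pair of measured compounds differs in one place alone, so no single-change step is known. Compound 4 `CCCc1cn(C/C=C(/C)CCC=C(C)C)nn1` is not yet measured in this assay. Against compound 3 it reads (hydrogen in place of pentyl on a saturated chain carbon, three bonds along the chain from an aromatic carbon). A decrease well beyond the scatter is expected, because compound 2 with propyl on the core gives 2.47. The expected step from compound 3 to compound 4 is a number 2.42 log units lower from compound 3 to compound 4 (beyond the scatter). Compound 4 is estimated at 4.5, within 3.9 to 5.2.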

Compound 4, partition coefficient: 4.05
Estimate against measurement, compound 4: 0.45 log units above; measured number inside the range.
By their numbers in this assay, from the lowest: compound 2; then compound 4; then compound 1; then compound 3.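

In this assay, among these compounds, hydrogen in place of pentyl on a saturated chain carbon, three bonds along the chain from an aromatic carbon, gives a number 2.87 log units lower from compound 3 to compound 4 (beyond the scatter) as the first single-change step at this place. 3-Methylbut-2-en-1-yl in place of hydrogen on a saturated chain carbon bound to a double-bonded chain carbon gives a number 1.58 log units higher from compound 2 to compound 4 (beyond the scatter) as the first at a second place. Both places therefore move the number beyond the scatter.

Going by these compounds, whether a chain ending in an amine or a carboxylic acid would follow these steps stays open. No measured evidence accounts for the size of either step.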